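One Methoxy Removed: What Paw Edema Inhibition Is Expected

The source may report more compounds than this note shows. Statements on the series, on what has been measured and on what is new or still open speak of the compounds shown alone.

Compound 1 `CCn1c(SCC(=O)Nc2ccc(/C(C)=N/O)cc2)nnc1-c1ccc(OC)cc1`: 73%
Compound 2 `CCn1c(SCC(=O)Nc2ccc(C(C)=O)cc2)nnc1-c1ccc(OC)c(OC)c1`: 69%
Compound 3 `CCn1c(SCC(=O)Nc2ccc(C(C)=O)cc2)nnc1-c1cc(OC)c(OC)c(OC)c1`: 68%

In a functional assay on the whole organism (strain albino) for inhibition, with Rattus norvegicus as the target, read by paw edema, with stated times of 30 min and 4 h, at a dose of 0.28 mmol/kg by the oral route (a lower number here means less inhibition, a higher number more inhibition at the dose given (going by the name of the read-out)), compound 1 gives 73%, compound 2 gives 69% and compound 3 gives 68%; all three numbers lie within the scatter of one another, so no order among them can be read. The cores of compound 1 and compound 3 differ, but that difference is not broken down here. Among the compounds with values here, the one counted change between measured compounds is hydrogen in place of methoxy on an aromatic carbon, and it gave a number 1 percentage points higher from compound 3 to compound 2 (within the scatter).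

Compound 4 `CCn1c(SCC(=O)Nc2ccc(/C(C)=N/O)cc2)nnc1-c1ccccc1` has not been measured. It differs from compound 1 by hydrogen in place of methoxy on an aromatic carbon. This is the same kind of change as that from compound 3 to compound 2, not the same one: there the place was ortho to a methoxy group, meta to a large group and meta to a methoxy group, whereas here it is para to a large group. Because a number 1 percentage points higher from compound 3 to compound 2 (within the scatter) stayed within the scatter, the step is expected to be small, a number 3 percentage points lower from compound 1 to compound 4 (within the scatter). Compound 4 is therefore estimated at 70%, expected to fall between 60% and 80%.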

Compound 4, a percentage reported as inhibition, in the whole organism at one dose (the size of the read-out at that dose, not a potency): 77%
Compound 4: the middle estimate sits 7 percentage points below what was measured; low and high end bracket the measured number.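

In this assay, the 4-methoxyphenyl to phenyl change gave a number 4 percentage points higher from compound 1 to compound 4 (within the scatter). Set beside the earlier case, the same change gave steps on the two cores that cannot be told apart: the same change on two cores in this assay, a number 1 percentage points higher (within the scatter) from compound 3 to compound 2 and a number 4 percentage points higher (within the scatter) from compound 1 to compound 4, 3 percentage points apart, within the scatter of two such steps. This shows that, in these two cases, replacing methoxy with hydrogen left the paw edema reading within the scatter on either core, so the small step carried over; it does not show a real rise on either core, and two cases at different places on the ring do not establish that the step would stay small on any further core.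

The compounds shown leave open what a chlorine atom, an amine or a carboxylic acid would do in place of the methoxy group at the same place on the ring. They also leave open whether a longer chain in place of the ethyl group would change the reading on either core.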